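A 4-bromophenyl swap in a narrow antiproliferative series

The source may hold more compounds than are shown below. What is called first, only, known or untested is meant among the compounds shown, and "the series" means these compounds.

Measured values in a functional assay on MGC-803 cells (Homo sapiens) for antiproliferative activity, read by MTT assay, with a stated time of 48 h (on this read-out higher numbers stand for weaker inhibition and lower numbers for stronger inhibition), are these:
- compound 1 `COc1cc(N(Cc2ccccc2)C(=O)CSc2nc3ccccc3s2)cc(OC)c1OC` gives 44300 nM in this read-out
- compound 2 `COc1ccc(CN(C(=O)CSc2nc3ccccc3s2)c2cc(OC)c(OC)c(OC)c2)cc1OC` gives 34100 nM in this read-out
- compound 3 `COc1ccc(CN(C(=O)CSc2nc3ccccc3s2)c2cc(OC)c(OC)c(OC)c2)cc1C(F)(F)F` gives 25200 nM in this read-out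

Compound 3 cannot be separated from the other two, since a 1.8-fold lower number from compound 1 to compound 3 (0.25 log units; within the scatter) and a 1.4-fold lower number from compound 2 to compound 3 (0.13 log units; within the scatter) are both within the scatter. Compound 4 `COc1cc(N(Cc2ccc(Br)cc2)C(=O)CSc2nc3ccccc3s2)cc(OC)c1OC` is not yet measured. It carries 4-bromophenyl in place of 4-methoxy-3-(trifluoromethyl)phenyl on a saturated chain carbon bound to an amide-type nitrogen.

Among the measured compounds shown here, two measured steps touch that same place. Compound 2 brings 3,4-dimethoxyphenyl in place of phenyl, with a 1.3-fold lower number from compound 1 to compound 2 (0.11 log units; within the scatter) as the result, and compound 3 brings 4-methoxy-3-(trifluoromethyl)phenyl in place of phenyl, with a 1.8-fold lower number from compound 1 to compound 3 (0.25 log units; within the scatter) as the result. Both are small and neither leaves the scatter. For the measured compounds named here, no compound with bromine has been measured, so the data say nothing direct about that group. From the compounds shown here alone, on this evidence, no step beyond the scatter is expected in this assay, and the direction stays open. The expected step is a 1.2-fold higher number from compound 3 to compound 4 (0.08 log units; within the scatter) in this estimate. For compound 4 the estimated value is 30000 nM, with an expected range from 13000 nM to 60000 nM in this assay.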

Compound 4, half-maximal inhibitory concentration: 48100 nM
Beside the measured number, compound 4's estimate is 1.6-fold (0.21 log units) below it; low and high end bracket the measured number.
By their numbers in this assay, from the lowest: compounds 3, 2, 1 and 4 (each within the scatter of the next).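

In this assay, among the compounds shown here, bromine appears at this place for the first time, and bromo in place of hydrogen on an aromatic carbon gives a 1.1-fold higher number from compound 1 to compound 4 (0.04 log units; within the scatter) and so no readable change from the unsubstituted phenyl. The swaps against the two other substituted rings, a 1.4-fold higher number from compound 2 to compound 4 (0.15 log units; within the scatter) and a 1.9-fold higher number from compound 3 to compound 4 (0.28 log units; within the scatter), also stay inside the scatter, so all four groups on the saturated chain carbon bound to an amide-type nitrogen now count as one level of activity, even though 4-bromophenyl and 4-methoxy-3-(trifluoromethyl)phenyl differ in size and in their atoms. No supporting measurement accompanies these numbers, so nothing can be said about why this position responds so little.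

The compounds shown leave open whether any group at this place can produce a step beyond the scatter, for example a ring carrying an amine or a carboxylic acid, or a longer chain in place of the single carbon that links the ring to the nitrogen. They also leave open whether bromine at another ring carbon, or chlorine at the same one, would read differently, and whether changes to the shared core matter more than changes here.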